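Moving the Methyl Around the Phenoxy Ring

This account rests on a few compounds, and the source may have more. Where it says the series, first, only, none or still open, it means among the compounds named here.

Three compounds share one core. In a functional assay on MCF7 cells (Homo sapiens) for cytotoxicity, read by trypan blue exclusion, with a stated time of 48 h (on this read-out higher numbers stand for weaker inhibition and lower numbers for stronger inhibition), compound 1 `O=C(COc1ccc(F)cc1)Nc1nc(-c2ccc(Br)cc2)cs1` gives 56800 nM. Compound 2 `Cc1ccccc1OCC(=O)Nc1nc(-c2ccc(Br)cc2)cs1` gives 39700 nM, and compound 3 `CC(C)c1ccccc1OCC(=O)Nc1nc(-c2ccc(Br)cc2)cs1` gives 43500 nM. Compound 2 has the lowest of the three numbers, yet the steps of a 1.4-fold lower number from compound 1 to compound 2 (0.16 log units; within the scatter) and a 1.1-fold higher number from compound 2 to compound 3 (0.04 log units; within the scatter) both fall within the scatter, so no ordering among the three can be claimed. Compound 4 `Cc1ccc(OCC(=O)Nc2nc(-c3ccc(Br)cc3)cs2)cc1` differs from compound 2 in one place: 4-methylphenyl in place of 2-methylphenyl on an oxygen on a saturated carbon. Both measured steps altered the same phenoxy group and neither shifted the read-out beyond the scatter, so a further change on that ring is expected to leave this assay essentially unchanged, a 1.1-fold higher number from compound 2 to compound 4 (0.02 log units; within the scatter). Compound 4 is therefore expected to give 42000 nM, within a range of 20000 nM to 85000 nM.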

Compound 4, half-maximal inhibitory concentration: 52400 nM
Compound 4: the middle estimate sits 1.2-fold (0.10 log units) below what was measured, and the stated range covers the measured number.
By their numbers in this assay, from the lowest: compounds 2, 3, 4 and 1 (each within the scatter of the next).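

In this assay, 4-methylphenyl in place of 2-methylphenyl on an oxygen on a saturated carbon gives a 1.3-fold higher number from compound 2 to compound 4 (0.12 log units; within the scatter) and so, with the same atoms joined differently, this read-out does not separate the two placements of the methyl. Methyl in place of fluoro on an aromatic carbon gives a 1.1-fold lower number from compound 1 to compound 4 (0.04 log units; within the scatter) and so this exchange on the same group also leaves the number unresolved. From the compounds shown here alone, whether an amine or a carboxylic acid in place of the methyl would carry the number beyond the scatter stays open. Nothing measured here bears on why these steps are so small.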